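Swapping a Chlorophenyl for a Hydroxyphenyl on One Core

The compounds below may be only part of what the source reports. "The series", "measured", "known", "first", "only" and "open" are said of these compounds alone.

Measured compounds:
compound 1, `O=C1CSC(c2c(Cl)cccc2Cl)N1CCN1CCCCC1`: 32%
compound 2, `O=C1CSC(c2cccc(Cl)c2)N1CCN1CCCCC1`: 45%

Both compounds were tested in an ADME assay on Vero cells (Chlorocebus sabaeus) for cytotoxicity, read by neutral red uptake, tested at 394 ug/mL (on this read-out higher numbers stand for a weaker effect at the one concentration tested and lower numbers for a stronger effect), where compound 1 gives 32% and compound 2 gives 45%. Of these two numbers, compound 2 stands highest, meaning the weaker effect on the cells; the gap to compound 1 lies beyond the usual scatter of this assay.

Compound 3, `O=C1CSC(c2ccc(O)cc2)N1CCN1CCCCC1`, has not yet been measured. It differs from compound 2 in one place: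
4-hydroxyphenyl in place of 3-chlorophenyl on a saturated ring carbon

Going by the values given here, no measured pair shows what exchanging a chlorine on the aromatic ring for a hydroxyl does here, so no direct precedent exists. Among the compounds with values here, with only two numbers known, both in a similar range, the step from compound 2 to compound 3 is expected to be small, a number 5 percentage points higher from compound 2 to compound 3 (within the scatter), in either direction or none beyond the scatter. On that basis compound 3 is expected to give about 50% in this assay, within a range from 25% to 75%.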

Compound 3, a percentage reported as activity, at one concentration (the size of the read-out at that concentration, not a potency): 76%
For compound 3 the middle estimate is 26 percentage points below the measured one; the whole stated range lies below it.
By their numbers in this assay, from the lowest: compound 1; then compound 2; then compound 3.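

In this assay, putting 4-hydroxyphenyl in place of 3-chlorophenyl on the saturated ring carbon gives a number 31 percentage points higher from compound 2 to compound 3 (beyond the scatter), so a change at this one position can move the read-out by a large amount. The group carried here therefore matters for the effect on the cells, and the compound with 4-hydroxyphenyl shows the weaker effect of this pair. No measurement at hand explains this rise.

This step changes both the group on the aromatic ring and its place on that ring, so a comparison with 3-hydroxyphenyl or 4-chlorophenyl would be needed to tell the two apart. The compounds shown also leave open how an amine or a carboxylic acid on the same aromatic ring would read.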